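Replacing a methyl with 4-fluorophenyl: what to expect

A few compounds are considered here, and "the series" means these few. Any claim that something is new, unique, unknown or untested is made for them only; others in the source may bear on it.

Compound 1 `CC(C)=CCOc1c(C)c(C)c2c(c1C)CCC(C)(COc1ccc(/C=C3\SC(=O)NC3=O)cc1F)O2` gives 64% in a functional assay on MCF7 cells (Homo sapiens), tested at 7.5 uM; a lower number here means a stronger effect, a higher number a weaker effect of the compound at the concentration tested.
Compound 2 `CC(C)=CCOc1c(C)c(C)c2c(c1C)CCC(C)(COc1ccc(/C=C3\SC(=O)NC3=O)cc1C)O2` gives 27% in this assay.
Compound 3 `C=CCOc1c(C)c(C)c2c(c1C)CCC(C)(COc1ccc(/C=C3\SC(=O)NC3=O)cc1C)O2` gives 8% in this assay.

Compound 2 stands second highest of the three numbers: nearest is compound 3, which lies lower, and furthest is compound 1, which lies higher. Compound 4 `CC(C)=CCOc1c(C)c(C)c2c(c1C)CCC(C)(COc1ccc(/C=C3\SC(=O)NC3=O)cc1-c1ccc(F)cc1)O2` differs from compound 2 by 4-fluorophenyl in place of methyl on an aromatic carbon. Among the compounds with values here, only one measured step touches that same aromatic carbon: a number 37 percentage points lower from compound 1 to compound 2 (beyond the scatter), a large move after a small swap of group. The other step, a number 19 percentage points lower from compound 2 to compound 3 (beyond the scatter), concerns a different part of the molecule and says little here. A far larger group now enters where a small change already moved the number strongly, so a step beyond the scatter seems likely, though its direction is uncertain. The expected step is a number 13 percentage points higher from compound 2 to compound 4 (beyond the scatter). Compound 4 is therefore estimated at 40%, within 10% to 75%.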

Compound 4, a percentage reported as activity, at one concentration (the size of the read-out at that concentration, not a potency): 85%
Compound 4: middle estimate off by 45 percentage points, on the low side; measured number above the stated range.
By their numbers in this assay, from the lowest: compound 3; then compound 2; then compound 1; then compound 4.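

In this assay the change from methyl to 4-fluorophenyl on this aromatic carbon brings a number 58 percentage points higher from compound 2 to compound 4 (beyond the scatter) and thus a much weaker effect at the concentration tested. The same group in place of fluoro brings a number 21 percentage points higher from compound 1 to compound 4 (beyond the scatter) as well, so among the three groups seen at this carbon, the number rises from methyl through fluoro to 4-fluorophenyl. Nothing available explains this order.

Going by these compounds, it remains open whether a plain phenyl or an ethyl would fall nearer to methyl or to 4-fluorophenyl. It is also unknown whether the order would hold with the shorter ether chain of compound 3.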